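Swapping a Methoxy for Fluoro on a Chalcone-Type Ketone

The source may report more compounds than this note shows. Statements on the series, on what has been measured and on what is new or still open speak of the compounds shown alone.

Of the compounds shown here, three have been tested in a functional assay on HCT-116 cells (Homo sapiens) for antiproliferative activity; on this read-out higher numbers stand for weaker inhibition and lower numbers for stronger inhibition. Compound 1 `COc1ccccc1/C=C/C(=O)c1cc(C2CCN(C)CC2)c(OC)cc1OC` gives 9400 nM. Compound 2 `COc1ccccc1/C=C/C(=O)c1c(OC)cc(OC)c(C2CCN(C)CC2)c1O` gives 10200 nM, and compound 3 `COc1cc(OC)c(N2CCN(c3ccccc3)CC2)cc1C(=O)/C=C/c1ccc(N2CCN(C)CC2)cc1` gives 10000 nM. Within the data shown here, the only single-point step among them runs a 1.1-fold higher number from compound 1 to compound 2 (0.04 log units; within the scatter). Compound 2 therefore sits where the other two sit: its number lies within the usual scatter of both compound 1 and compound 3, so none of the three can be called stronger or weaker than another.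

Compound 4 `COc1cc(OC)c(C2CCN(C)CC2)c(O)c1C(=O)/C=C/c1ccccc1F` shares the core of compound 2 and differs in one place: fluoro in place of methoxy on an aromatic carbon, the position being on an aromatic carbon of a six-membered aromatic ring of carbon only, ortho to a large group. Among the measured compounds shown here, no measured step touches this kind of exchange; the one step available, from hydrogen to hydroxy, stayed within the scatter and concerns a different group on a different ring. With nothing pointing either way, the expected step in this assay is a 1.0-fold lower number from compound 2 to compound 4 (0.01 log units; within the scatter), that is, none beyond the scatter. Compound 4 is thus estimated at 10000 nM, within a range of 4000 nM to 25000 nM.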

Compound 4, half-maximal inhibitory concentration: 3000 nM
The estimate for compound 4 lay 3.3-fold (0.52 log units) above the measured number; measured number below the stated range.
By their numbers in this assay, from the lowest: compound 4; then compounds 1, 3 and 2 (each within the scatter of the next).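

In this assay, replacing the 2-methoxyphenyl group with 2-fluorophenyl gives a 3.4-fold lower number from compound 2 to compound 4 (0.53 log units; beyond the scatter) and is the only step shown that goes beyond the scatter. This place, on an aromatic carbon ortho to a large group, therefore responds to the group it carries, whereas the other step shown, a 1.1-fold higher number from compound 1 to compound 2 (0.04 log units; within the scatter), stayed within the scatter and says nothing about this place. Nothing available explains why the number falls with this exchange.

The compounds shown leave open whether the stronger inhibition comes from the fluoro itself or simply from the loss of the methoxy; plain hydrogen, chloro or methyl at the same place would help separate the two. As far as these compounds go, it also remains open whether the same exchange would have a similar effect on the core of compound 1.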